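Replacing a Methoxyphenyl Amine with a Nitrophenyl Amine

The source may report more compounds than this note shows. Statements on the series, on what has been measured and on what is new or still open speak of the compounds shown alone.

Three compounds share one core and differ only in the group on the ring nitrogen. Compound 1 `CCCCCCNc1nc(SCc2ccc(C(F)(F)F)cc2)nc2ccccc12` carries a hexyl group and gives 23900 nM in a functional assay on HGC-27 cells (Homo sapiens) for cytotoxicity, read by MTT assay, with a stated time of 72 h; a lower number here means a stronger inhibitor, a higher number a weaker inhibitor. Compound 2 `CCCCCCCCCCCCNc1nc(SCc2ccc(C(F)(F)F)cc2)nc2ccccc12` carries a dodecyl group; in this assay compound 2 gives 38700 nM, and a 1.6-fold higher number from compound 1 to compound 2 (0.21 log units; within the scatter). Compound 3 `COc1ccccc1Nc1nc(SCc2ccc(C(F)(F)F)cc2)nc2ccccc12` carries a 2-methoxyphenyl group. In this assay compound 3 reaches only the limit > 50000 nM, so only a limit is known for it (the limit of > 50000 nM in this assay, at which 1 of the 3 values shown sits). Even so, an at least 2.0-fold higher number from compound 1 to compound 3 (0.32 log units; beyond the scatter). Compound 4 `O=[N+]([O-])c1cccc(Nc2nc(SCc3ccc(C(F)(F)F)cc3)nc3ccccc23)c1` is not yet measured; it differs from compound 3 by 3-nitrophenyl in place of 2-methoxyphenyl on a nitrogen on an aromatic ring. For the measured compounds named here, only the step from compound 1 to compound 3 concerns an aryl group on that nitrogen, and it pointed to a weaker inhibitor. Compound 4 is therefore expected to give 60000 nM, with a range from 25000 nM to 150000 nM. The step that the limit leaves unreadable from compound 3 to compound 4 is thus expected to stay within the scatter.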

Compound 4, half-maximal inhibitory concentration: > 50000 nM
Compound 4: a limit, no number; the forecaster's own chance of this, stated with the estimate: 65%; the middle value is on the limit's open side.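

In this assay compound 4 gives > 50000 nM as a limit, not a number. A second aryl group on that nitrogen thus behaves like the first, with an at least 2.0-fold higher number from compound 1 to compound 4 (0.32 log units; beyond the scatter) as the comparison with the hexyl group. The step between the two aryl compounds cannot be read, since both stop at the same limit: the limit of > 50000 nM in this assay, at which 2 of the 4 values shown sit.

On these data alone, whether any aryl group on that nitrogen can give a real number stays open, for instance 3-aminophenyl. So does the effect of a butyl chain there.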